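Swapping methoxy for fluoro on a weakly active isoxazole analogue

This account rests on a few compounds, and the source may have more. Where it says the series, first, only, none or still open, it means among the compounds named here.

Measured compounds:
compound 1, `CCOC(=O)C1=Cc2ccccc2OC1(OCc1cn(-c2ccc(F)cc2)nn1)C(F)(F)F`: 7300 nM
compound 2, `CCOC(=O)C1=Cc2ccccc2OC1(OCc1cc(-c2ccc(OC)cc2)no1)C(F)(F)F`: > 150000 nM

Of the compounds shown here, two sharing one core have been tested in a functional assay on A549 cells (Homo sapiens) for inhibition, read by MTT assay, with a stated time of 24 h; on this read-out lower numbers stand for stronger inhibition and higher numbers for weaker inhibition. Compound 1 has the structure `CCOC(=O)C1=Cc2ccccc2OC1(OCc1cn(-c2ccc(F)cc2)nn1)C(F)(F)F` and in this assay compound 1 gives 7300 nM. Compound 2 has the structure `CCOC(=O)C1=Cc2ccccc2OC1(OCc1cc(-c2ccc(OC)cc2)no1)C(F)(F)F`. In this assay compound 2 reaches only a limit of the assay, > 150000 nM, so no number is known for it; it sits at the limit of > 150000 nM in this assay, at which 1 of the 2 values shown sits. For the measured compounds named here, compound 1 and compound 2 differ in more than one place, so their two values show only that one returns a number while the other does not.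

The step to be followed leads from compound 2 to compound 3, whose structure is `CCOC(=O)C1=Cc2ccccc2OC1(OCc1cc(-c2ccc(F)cc2)no1)C(F)(F)F`. The change is fluoro in place of methoxy on an aromatic carbon. Going by the values given here, no measured step of the same kind is available here, so the direction rests on the single value of compound 2, which is a limit. The step from compound 2 to compound 3 is expected to be an at least 2.5-fold lower number from compound 2 to compound 3 (0.39 log units; beyond the scatter), toward stronger inhibition but not with confidence. Compound 3 is estimated at 60000 nM, within 10000 nM to 200000 nM.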

Compound 3, half-maximal inhibitory concentration: 35500 nM
Estimate against measurement, compound 3: 1.7-fold (0.23 log units) above, within the range that was stated.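

In this assay, the move from 4-methoxyphenyl to 4-fluorophenyl takes the series from a compound with no number to one with a number, as compound 3 gives 35500 nM. Fluoro in place of methoxy, on an aromatic carbon para to a large group, gives an at least 4.2-fold lower number from compound 2 to compound 3 (0.62 log units; beyond the scatter), so this position does respond to what is placed on it. That size is only a floor, since the value of compound 2 is a limit of the assay and not a number: the limit of > 150000 nM in this assay, at which 1 of the 3 values shown sits.

With only these two groups at this position, a single step cannot separate a gain from fluoro from a loss caused by methoxy, and a plain hydrogen, a chlorine or an amine in the same place would help to tell these apart. Going by these compounds, it also stays open whether the same swap would shift the number to a similar extent on the core of compound 1, which already carries the 4-fluorophenyl group and gives 7300 nM.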